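The compounds below may be only part of what the source reports. "The series", "measured", "known", "first", "only" and "open" are said of these compounds alone.

Compound 1 `CC(C)C[C@H](N)c1cc(C(F)(F)F)ccc1N1CCN(C(=O)CC(C)C(=O)c2ccc(Cl)cc2)CC1`: 1100 nM
Compound 2 `CC(C)C[C@H](N)c1cc(F)ccc1N1CCN(C(=O)C(C)Cc2ccc(Cl)cc2)CC1`: 390 nM
Compound 3 `COc1cc(Cl)ccc1C[C@@H](C)C(=O)N1CCN(c2ccc(C)cc2[C@@H](N)CC(C)C)CC1`: 8.1 nM

In an assay on HEK293 cells for displacement of a labelled ligand from Melanocortin receptor 4 (Homo sapiens) (a lower number here means a stronger inhibitor, a higher number a weaker inhibitor), compound 1 gives 1100 nM, the highest number of the three measured compounds. Compound 2 gives 390 nM, and compound 3 gives 8.1 nM, both lower than compound 1 and both beyond the usual scatter of this assay. Within the data shown here, none of these three pairs differs in only one place, so no single step can be read from them; they show only that changes to the amide side chain and to the substituent on the shared core move the numbers over a wide range.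

Compound 4 `CC(C)C[C@H](N)c1cc(C(F)(F)F)ccc1N1CCN(C(=O)CCC2CCCCC2)CC1` keeps the core of compound 1 and changes only the amide side chain: cyclohexylmethyl in place of 1-((4-chlorophenyl)carbonyl)ethyl on a saturated chain carbon bound to a carbonyl carbon. Among the measured compounds shown here, the carbonyl and the aromatic ring that leave, and the saturated ring that enters, have no measured counterpart among compounds 2 and 3, so the direction of the step is uncertain. The expected step from compound 1 to compound 4 is a 1.4-fold lower number from compound 1 to compound 4 (0.14 log units; within the scatter), not beyond the scatter in either direction. Compound 4 is therefore estimated at 800 nM in this assay, with a range from 200 nM to 4000 nM.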

Compound 4, inhibition constant: 5700 nM
Estimate against measurement, compound 4: 7.1-fold (0.85 log units) below; the measured number lies above the stated range.
By their numbers in this assay, from the lowest: compound 3; then compound 2; then compound 1; then compound 4.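

Among these compounds, at the saturated chain carbon bound to a carbonyl carbon, this is the first change that can be read in one place: in this assay, cyclohexylmethyl in place of 1-((4-chlorophenyl)carbonyl)ethyl gives a 5.2-fold higher number from compound 1 to compound 4 (0.71 log units; beyond the scatter). Among the compounds shown here, with the rest of compound 1 held fixed, the side chain alone therefore moves the number beyond the scatter, and the side chain with the carbonyl and the chlorinated aromatic ring is the one with the lower number. Nothing measured here accounts for this rise.

On these data alone, the carbonyl, the chlorine and the aromatic ring all leave in this one step, so it remains open which of them matters. A benzyl group without chlorine, or a hydroxyl in place of the carbonyl, at this place would begin to separate them.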